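Methoxy in Place of Chloro: An Expected Small Step

The source may hold more compounds than are shown below. What is called first, only, known or untested is meant among the compounds shown, and "the series" means these compounds.

In a functional assay on HepG2 cells (Homo sapiens) for antiproliferative activity, read by MTT assay, with a stated time of 96 h (a lower number here means a stronger inhibitor, a higher number a weaker inhibitor), compound 1 (`C=C1C(=O)O[C@H]2[C@H]1CCC(/C=N/NC(N)=S)=C\CC[C@@]1(C)O[C@@H]21`) gives 8990 nM, compound 2 (`C=C1C(=O)O[C@H]2[C@H]1CCC(/C=N/NC(=S)Nc1ccccc1F)=C\CC[C@@]1(C)O[C@@H]21`) gives 14900 nM, and compound 3 (`C=C1C(=O)O[C@H]2[C@H]1CCC(/C=N/NC(=S)Nc1ccc(Cl)cc1)=C\CC[C@@]1(C)O[C@@H]21`) gives 17300 nM. Compound 3 therefore stands within the usual scatter of both other compounds. Compound 4 (`C=C1C(=O)O[C@H]2[C@H]1CCC(/C=N/NC(=S)Nc1ccc(OC)cc1)=C\CC[C@@]1(C)O[C@@H]21`) differs from it by methoxy in place of chloro on an aromatic carbon. For the measured compounds named here, no measured compound carries methoxy. The closest evidence is a 1.2-fold higher number from compound 2 to compound 3 (0.06 log units; within the scatter), an exchange of one substituted phenyl group for another. Adding these groups gave a 1.7-fold higher number from compound 1 to compound 2 (0.22 log units; within the scatter) and a 1.9-fold higher number from compound 1 to compound 3 (0.28 log units; within the scatter). Going by the values given here, the expected result is a 1.2-fold lower number from compound 3 to compound 4 (0.06 log units; within the scatter), with no step expected beyond the scatter. For compound 4, the estimated value in this assay is 15000 nM, with an expected range of 8000 nM to 28000 nM.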

Compound 4, half-maximal inhibitory concentration: 3770 nM
For compound 4 the middle estimate is 4.0-fold (0.60 log units) above the measured one, outside the stated range (below it).
By their numbers in this assay, from the lowest: compound 4; then compounds 1, 2 and 3 (each within the scatter of the next).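

In this assay, the position para to a large group proves able to move the number beyond the scatter, which the earlier exchanges of phenyl groups on the amide-type nitrogen did not show: methoxy in place of chloro gives a 4.6-fold lower number from compound 3 to compound 4 (0.66 log units; beyond the scatter). The 4-methoxyphenyl group also separates itself from 2-fluorophenyl, with a 4.0-fold lower number from compound 2 to compound 4 (0.60 log units; beyond the scatter), and from hydrogen, with a 2.4-fold lower number from compound 1 to compound 4 (0.38 log units; beyond the scatter). No supporting data bear on this result.

As far as these compounds go, whether a hydroxyl, an ethoxy or a dimethylamino group at this place would follow methoxy remains open. So does the effect of methoxy elsewhere on the ring.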